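This account rests on a few compounds, and the source may have more. Where it says the series, first, only, none or still open, it means among the compounds named here.

Compound 1 `Nc1cc(C2CCC2)nc2ccc(NC(=O)/C=C/c3ccc(C(F)(F)F)cc3)cc12` gives 2 nM in an assay on isolated protein for displacement of a labelled ligand from melanin-concentrating hormone receptor 1 (Homo sapiens); on this read-out lower numbers stand for stronger inhibition and higher numbers for weaker inhibition. That is the lowest of the three numbers recorded so far, though compound 2 `CCCc1cc(N2CCC2)c2cc(NC(=O)/C=C/c3ccc(C(F)(F)F)cc3)ccc2n1`, at 2.8 nM, sits within the scatter of it, so the two cannot be ordered against each other; only compound 3 `CCCc1cc(N)c2cc(NC(=O)/C=C/c3ccc(SC)cc3)ccc2n1`, at 9 nM, stands clearly apart from compound 1. Compound 4 `Nc1cc(-c2ccccc2)nc2ccc(NC(=O)/C=C/c3ccc(C(F)(F)F)cc3)cc12` has not been measured. It differs from compound 1 in one place: phenyl in place of cyclobutyl on an aromatic carbon. Within the data shown here, compounds 2 and 3 differ from compound 1 in more than one place, so no measured step isolates this particular change, and the estimate rests on the general closeness of the three numbers. The expectation is a modest weakening, a step of a 2.5-fold higher number from compound 1 to compound 4 (0.40 log units; beyond the scatter) in this assay that may well fall inside the usual scatter. Compound 4 is therefore expected to give about 5 nM in this assay, with the likely range running from 1.5 nM to 20 nM.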

Compound 4, half-maximal inhibitory concentration: 18.5 nM
Compound 4: middle estimate off by 3.7-fold (0.57 log units), on the low side; the range from low to high includes it.
By their numbers in this assay, from the lowest: compounds 1 and 2 (each within the scatter of the next); then compound 3; then compound 4.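

In this assay, among these compounds, phenyl in place of cyclobutyl on this aromatic carbon, next to the ring nitrogen, gives a 9.3-fold higher number from compound 1 to compound 4 (0.97 log units; beyond the scatter) and so supplies the only single-place step measured here. The position is therefore not indifferent to the group it carries, and a six-membered aromatic ring of carbon does not stand in for a four-membered non-aromatic one, even though neither group has hydrogen-bond donors, hydrogen-bond acceptors or a net charge. Nothing shown accounts for the size of this step.

Still open, from the compounds shown here alone, is how a cyclohexyl or cyclopentyl ring would read at this carbon, which would help separate ring size from aromatic character. Also open, going by these compounds, is whether a pyridyl ring, or a phenyl ring carrying a fluorine or a methoxy group, would stand nearer to compound 1 or to compound 4.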